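A few compounds are considered here, and "the series" means these few. Any claim that something is new, unique, unknown or untested is made for them only; others in the source may bear on it.

Measured compounds:
Compound 1 `COc1ccc2[nH]c(C(=O)N3CC(=O)N(Cc4ccccc4)[C@@H](CN4CCC5(CC4)CC5)C3)cc2c1`: 28200 nM
Compound 2 `O=C(c1cc2cc(C3CC3)ccc2[nH]1)N1CC(=O)N(Cc2ccccc2)[C@@H](CN2CCC(F)CC2)C1`: 12400 nM
Compound 3 `COc1ccc2[nH]c(C(=O)N3CC(=O)N(Cc4ccccc4)[C@@H](N4CCC(Cc5ccccc5)CC4)C3)cc2c1`: 9300 nM

In a physicochemical assay for solubility, read by spectrophotometry, in phosphate buffer, with a stated time of 2 h, at pH 7.4 (a lower number here means a less soluble compound, a higher number a more soluble compound), compound 1 gives the highest number of the three. Compound 2 lies lower, and compound 3 lower again, both beyond the scatter from compound 1, while the two of them lie within the scatter of each other and so cannot be ordered.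

Compound 4 `COc1ccc2[nH]c(C(=O)N3CC(=O)N(Cc4ccccc4)[C@@H](CN4CCC5(CCCC5)CC4)C3)cc2c1` is not yet measured. It differs from compound 1 in one place: a group of 10 heavy atoms (9 carbon, 1 nitrogen; one five-membered non-aromatic ring of carbon only, one six-membered non-aromatic ring with 1 hetero atom) in place of a group of 8 heavy atoms (7 carbon, 1 nitrogen; one three-membered non-aromatic ring of carbon only, one six-membered non-aromatic ring with 1 hetero atom), on a saturated chain carbon bound to a saturated ring carbon. For the measured compounds named here, no measured pair shows this exact change, so the expectation rests only on the two structures. A modest fall in solubility is expected, by a step of a 2.4-fold lower number from compound 1 to compound 4 (0.37 log units; beyond the scatter). For compound 4 the estimated value in this assay is 12000 nM, with a range from 5000 nM to 28000 nM.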

Compound 4, solubility: 5000 nM
The estimate for compound 4 lay 2.4-fold (0.38 log units) above the measured number; the range from low to high includes it.
By their numbers in this assay, from the lowest: compounds 4, 3 and 2 (each within the scatter of the next, the first and the last beyond it); then compound 1.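

In this assay, a five-membered carbon ring in place of a three-membered carbon ring, on the same saturated chain carbon, gives a 5.6-fold lower number from compound 1 to compound 4 (0.75 log units; beyond the scatter) in a pair with the rest of the molecule unchanged. For the compounds shown here, the earlier compounds formed no such pair, so this is the first fall that can be tied to one change. Nothing measured here explains it.

A four-membered carbon ring, or an oxetane, in the same place would show whether the fall tracks ring size. Going by these compounds, it also remains open whether this step holds on another core.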